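A few compounds are considered here, and "the series" means these few. Any claim that something is new, unique, unknown or untested is made for them only; others in the source may bear on it.

Of the compounds shown here, three sharing one core have been tested in a functional assay on A549 cells (Homo sapiens) for cytotoxicity, read by MTT assay, with a stated time of 48 h; on this read-out lower numbers stand for stronger inhibition and higher numbers for weaker inhibition. Compound 1 `CCc1nnc(SCc2ccccc2)n1N1C(=O)c2ccccc2C1=O` gives only > 200000 nM, which is a limit of the assay and not a number. Compound 2 `C=CCSc1nnc(-c2cc(OC)c(OC)c(OC)c2)n1N1C(=O)c2ccccc2C1=O` likewise reaches only the limit > 200000 nM. Within the data shown here, compound 3 `COc1cc(-c2nnc(SCC(=O)c3ccc(Cl)cc3)n2N2C(=O)c3ccccc3C2=O)cc(OC)c1OC` gives 9030 nM, and it stands as the only number among the three, the other two resting at the limit of > 200000 nM in this assay, at which 2 of the 3 values shown sit. Among the measured compounds shown here, the one step that can be sized, an at least 22-fold lower number from compound 2 to compound 3 (1.34 log units; beyond the scatter), shows that bringing a (4-chlorophenyl)carbonyl onto the saturated chain carbon bound to the sulfur goes together with a much lower number.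

Compound 4 `COc1cc(-c2nnc(SCc3ccccc3)n2N2C(=O)c3ccccc3C2=O)cc(OC)c1OC` differs from compound 3 by phenyl in place of (4-chlorophenyl)carbonyl on a saturated chain carbon bound to a sulfur. The measured step that bears on this change is the large one just described, in which the (4-chlorophenyl)carbonyl entered at this very place; the change to compound 4 takes that group away again, leaving a benzylsulfanyl. Compound 1 carries the same benzylsulfanyl on a different core and sits at a limit. A step toward a higher number, possibly back to the limit, is therefore expected in this assay. Compound 4 is estimated at about 120000 nM, within a range from 20000 nM to 200000 nM. This estimate means an expected step of a 13-fold higher number from compound 3 to compound 4 (1.12 log units; beyond the scatter).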

Compound 4, half-maximal inhibitory concentration: > 200000 nM
Compound 4: a limit, no number; the forecaster's own chance of this, stated with the estimate: 50%; middle value at least 1.6-fold (0.22 log units) away from the limit.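

In this assay, the change to phenyl on the saturated chain carbon bound to a sulfur gives an at least 22-fold higher number from compound 3 to compound 4 (1.34 log units; beyond the scatter). The earlier step compared the (4-chlorophenyl)carbonyl only with vinyl, whereas compound 4 keeps a six-membered aromatic ring of carbon at this place and still yields no number, so within this pair a ring alone is not enough and the lower number goes with the carbonyl and the chlorine that leave. Compound 4 gives > 200000 nM, which is a limit of the assay and not a number, and the steps to it from compound 1 and compound 2 cannot be read, as each has a limit at both ends: the limit of > 200000 nM in this assay, at which 3 of the 4 values shown sit.

The compounds shown do not separate the carbonyl from the chlorine, since both leave together in this one change. A phenylcarbonyl without the chlorine, a 4-chlorobenzyl without the carbonyl, or an amine on the same chain would each test a different part of the group, and only compound 3 so far offers a number to compare them with.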